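Diaminoquinoxaline series: benzylamine swap toward methoxy

This account rests on a few compounds, and the source may have more. Where it says the series, first, only, none or still open, it means among the compounds named here.

Going by the values given here, the shared core is read in a functional assay on K562 cells (Homo sapiens) for inhibition, read by sulforhodamine B assay, with a stated time of 48 h (on this read-out higher numbers stand for weaker inhibition of growth and lower numbers for stronger inhibition of growth), on two compounds so far. Compound 1 `CCOC(=O)[C@H](CCC(=O)O)NC(=O)c1ccc(CNc2nc3cc(N)cc(N)c3nc2-c2ccccc2)cc1` carries a benzyl group bearing an ester-capped glutamate amide and gives 8710 nM. Compound 2 `Nc1cc(N)c2nc(-c3ccccc3)c(NCc3ccc(Cl)c(Cl)c3)nc2c1` carries a 3,4-dichlorobenzyl group and gives 3090 nM; it stands at the lowest of the two numbers, and its gap to compound 1 is beyond the usual scatter of this assay, so among the measured pair compound 2 is the stronger inhibitor of growth.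

The next compound, compound 3 `COc1ccc(CNc2nc3cc(N)cc(N)c3nc2-c2ccccc2)cc1`, differs from compound 2 in one place: 4-methoxyphenyl in place of 3,4-dichlorophenyl on a saturated chain carbon bound to a nitrogen on an aromatic ring. Among the compounds with values here, no measured pair isolates this exchange, so the size of the step has no direct precedent here. A moderate rise in the number is expected, meaning weaker inhibition of growth, with the step from compound 2 to compound 3 estimated at a 2.1-fold higher number from compound 2 to compound 3 (0.32 log units; beyond the scatter), which may sit at the edge of the scatter rather than clearly beyond it. Compound 3 is therefore expected to give about 6500 nM in this assay, within a range of 2500 nM to 17000 nM.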

Compound 3, concentration for 50% growth inhibition: 25100 nM
The estimate for compound 3 lay 3.9-fold (0.59 log units) below the measured number, and the stated range ends below it.
By their numbers in this assay, from the lowest: compound 2; then compound 1; then compound 3.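

In this assay, going by these compounds alone, the exchange of 3,4-dichlorophenyl for 4-methoxyphenyl on a saturated chain carbon bound to a nitrogen on an aromatic ring gives an 8.1-fold higher number from compound 2 to compound 3 (0.91 log units; beyond the scatter), the first single-place step and one that shows growth inhibition depends on the substituents of this ring. The leaving and entering groups both count 8 heavy atoms and one six-membered aromatic ring of carbon only, so heavy-atom count and ring type do not account for the step, although the entering group differs in carrying 1 hydrogen-bond acceptor. No measurement here bears on the reason for the step.

The compounds shown leave open whether the step follows from losing the two chlorine atoms, from adding the methoxy group, or from both, which a 4-chlorophenyl, 3-chlorophenyl or unsubstituted phenyl group at the same place could separate. A 3,4-dimethoxyphenyl or 4-hydroxyphenyl group would likewise test how far the drop in this series belongs to the oxygen substituent itself.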